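Swapping a cyanobenzyl for a bromobenzyl: expected cytotoxicity

The compounds below may be only part of what the source reports. "The series", "measured", "known", "first", "only" and "open" are said of these compounds alone.

Compound 1, `O=c1ccoc2cc(OCc3cn(Cc4ccc([N+](=O)[O-])cc4)nn3)ccc12`, gives > 300000 nM in an ADME assay on L02 cells (Homo sapiens) for cytotoxicity, read by MTT assay, with a stated time of 48 h; on this read-out lower numbers stand for stronger inhibition and higher numbers for weaker inhibition.
Compound 2, `N#Cc1ccc(Cn2cc(COc3ccc4c(=O)ccoc4c3)nn2)cc1`, gives > 300000 nM in this assay.

Both values above are limits of the measurement, not numbers. Among the measured compounds shown here, the only measured step, cyano in place of nitro on an aromatic carbon, is a step that the two limits leave unreadable from compound 1 to compound 2. Compound 2 therefore stands at the limit of > 300000 nM in this assay, at which 2 of the 2 values shown sit, with nothing more known about it than that limit.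

Compound 3, `O=c1ccoc2cc(OCc3cn(Cc4ccccc4Br)nn3)ccc12`, differs from compound 2 by 2-bromophenyl in place of 4-cyanophenyl on a saturated chain carbon bound to an aromatic nitrogen. For the measured compounds named here, the single measured step bears on this change only in that it could not be read, so it offers no size or direction to carry over; no step beyond the scatter is expected.

Compound 3 is expected to give 300000 nM in this assay, with a range of 100000 nM to 1000000 nM, most probably again reported only as a limit. This expectation means a step of a number no higher from compound 2 to compound 3 (the limit leaves the size open).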

Compound 3, half-maximal inhibitory concentration: > 300000 nM
Compound 3: a limit, no number; the forecaster's own chance of this, stated with the estimate: 85%; the middle value sits exactly at the limit.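

No step among compound 1, compound 2 and compound 3 can be read, because all three give a limit of the measurement rather than a number: the limit of > 300000 nM in this assay, at which 3 of the 3 values shown sit.

From the compounds shown here alone, whether 4-nitrophenyl, 4-cyanophenyl and 2-bromophenyl differ at all in this assay stays open.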